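This account rests on a few compounds, and the source may have more. Where it says the series, first, only, none or still open, it means among the compounds named here.

Measured so far:
compound 1 `N#CN/C(=N\CCCCCNC(=O)c1ccccc1)NCCCOc1cccc(CN2CCCCC2)c1` — 6.58
compound 2 `N#CN/C(=N\CCNC(=O)CCc1ccccc1)NCCCOc1cccc(CN2CCCCC2)c1` — 6.27

In a functional assay on cardiac atrium for antagonist activity at histamine H2 receptor (Cavia porcellus) (on this read-out lower numbers stand for lower potency and higher numbers for higher potency (the scale is a negative logarithm)), compound 2 stands lowest of the two measured compounds; its nearest neighbour is compound 1, and the move was a number 0.31 log units lower from compound 1 to compound 2 (beyond the scatter). Compound 3 `N#CN/C(=N\CCNC(=O)CCCc1ccccc1)NCCCOc1cccc(CN2CCCCC2)c1` carries the change (benzyl in place of phenyl on a saturated chain carbon, two bonds along the chain from a carbonyl carbon), that is, the same amide chain extended by one carbon toward the aromatic ring. Within the data shown here, only that one measured step bears on this region, and it was modest; no closer comparison exists. A step of similar or smaller size is expected, with no clear direction, so a number 0.03 log units higher from compound 2 to compound 3 (within the scatter) is expected to stay near the scatter. Compound 3 is estimated at 6.3, within 5.8 to 6.8.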

Compound 3, negative logarithm of the antagonist equilibrium constant: 6.45
Estimate against measurement, compound 3: 0.15 log units below, and the stated range covers the measured number.
By their numbers in this assay, from the lowest: compounds 2, 3 and 1 (each within the scatter of the next, the first and the last beyond it).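

In this assay benzyl in place of phenyl gives a number 0.18 log units higher from compound 2 to compound 3 (within the scatter) and so does not separate these two chains. The step of a number 0.13 log units lower from compound 1 to compound 3 (within the scatter) shows that ((3-phenylpropyl)carbonyl)amino and 3-benzamidopropyl cannot be told apart here, whereas (phenethylcarbonyl)amino and 3-benzamidopropyl could be. Nothing available explains these steps.

As far as these compounds go, it remains open whether a longer chain, such as 4-phenylbutyl on the carbonyl, stays within the scatter of compound 3. From the compounds shown here alone, it is also open whether an amine or a carboxylic acid on that chain would move the number.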